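Swapping the Ring Nitrogen Substituent on the Acid Analogue

The compounds below may be only part of what the source reports. "The series", "measured", "known", "first", "only" and "open" are said of these compounds alone.

Measured compounds:
compound 1, `CC1=NN(c2ccc(C)c(C)c2)C(=O)/C1=C(/C)NNC(=S)N1CCc2cc(C(=O)N3CCOCC3)ccc21`, 31 nM
compound 2, `CC1=NN(c2ccc3c(c2)CCC3)C(=O)/C1=C(/C)NNC(=O)N1CCc2cc(C(=O)O)ccc21`, 46 nM
compound 3, `CNC(=O)c1ccc2c(c1)CCN2C(=S)NN/C(C)=C1\C(=O)N(c2ccc(C)c(C)c2)N=C1C`, 22 nM

In an assay on BaF3 cells for inhibition of thrombopoietin receptor (Homo sapiens) (on this read-out higher numbers stand for an effect only at larger amounts of compound and lower numbers for an effect already at smaller amounts), compound 2 gives 46 nM. Its number lies within the scatter of the number of compound 1, while its gap to compound 3 lies beyond the scatter. Compound 4, `CC1=NN(c2ccc(C)c(C)c2)C(=O)/C1=C(/C)NNC(=O)N1CCc2cc(C(=O)O)ccc21`, has not yet been measured. It differs from compound 2 in one place: 3,4-dimethylphenyl in place of 2,3-dihydro-1H-inden-5-yl on an amide-type nitrogen in a ring. Going by the values given here, the only measured step, a 1.4-fold lower number from compound 1 to compound 3 (0.15 log units; within the scatter), concerns a different position, the carbonyl-bearing group, and not the ring nitrogen substituent, so no measured step bears directly on the change from compound 2 to compound 4. Compounds 1 and 3 both carry the 3,4-dimethylphenyl group that enters, but they also differ from compound 4 elsewhere, so their values cannot be taken as a direct guide. The expectation for compound 4 is therefore a step of a 1.2-fold lower number from compound 2 to compound 4 (0.06 log units; within the scatter), that is, none beyond the scatter. Compound 4 is estimated at 40 nM, within a range from 15 nM to 120 nM.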

Compound 4, half-maximal effective concentration: 42 nM
Compound 4: the middle estimate sits 1.1-fold (0.02 log units) below what was measured; the range from low to high includes it.
By their numbers in this assay, from the lowest: compounds 3, 1, 4 and 2 (each within the scatter of the next, the first and the last beyond it).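

In this assay, going by these compounds alone, 3,4-dimethylphenyl in place of 2,3-dihydro-1H-inden-5-yl on the amide-type nitrogen in a ring gives a 1.1-fold lower number from compound 2 to compound 4 (0.04 log units; within the scatter), the first measured step at this position. The two groups cannot be told apart on this read-out, so the five-membered non-aromatic ring of carbon only in the leaving group is not required for a number of this size, at least with the rest of compound 2 in place. No measurement shown here offers a reason for this match.

Still open, as far as these compounds go, is whether a group of another kind at this place, such as a pyridine ring or a phenyl ring carrying an amine, would also match. From the compounds shown here alone, it is also open whether the match holds alongside the carbonyl-bearing groups of compound 1 and compound 3, which differ from compound 4 in more than one place.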